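Adding a Hydroxy Group to a Weakly Cytotoxic Hydrazone

This account rests on a few compounds, and the source may have more. Where it says the series, first, only, none or still open, it means among the compounds named here.

Compound 1 `O=C(N/N=C/c1cc(I)cc(I)c1O)c1ccccc1` and compound 2 `O=C(N/N=C/c1cc(I)c(O)c(I)c1)c1ccccc1` share a core and were both tested in a functional assay on HepG2 cells (Homo sapiens) for cytotoxicity, with a stated time of 24 h; on this read-out lower numbers stand for stronger inhibition and higher numbers for weaker inhibition. For compound 1 the result is only a limit of the assay, > 50000 nM. In this assay, within the data shown here, compound 2 gives 191000 nM, the single numerical value available, and so serves as the point of comparison. Compound 3 `O=C(N/N=C/c1cc(I)c(O)c(I)c1)c1ccc(O)cc1` differs from compound 2 by hydroxy in place of hydrogen on an aromatic carbon. Among the measured compounds shown here, no measured pair isolates this change. The step of a 1.3-fold lower number from compound 2 to compound 3 (0.10 log units; within the scatter) is expected to be small, with no clear direction beyond the scatter. Compound 3 is therefore estimated at about 150000 nM, between 50000 nM and 400000 nM.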

Compound 3, half-maximal inhibitory concentration: 110000 nM
Compound 3: middle estimate off by 1.4-fold (0.13 log units), on the high side; low and high end bracket the measured number.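

Among these compounds, replacing hydrogen with hydroxy, which turns phenyl into 4-hydroxyphenyl, gives the first measured step for this change in this assay: a 1.7-fold lower number from compound 2 to compound 3 (0.24 log units; within the scatter). At this place on the ring, then, the added hydroxy causes no shift that can be told apart from repeat-measurement noise.

From the compounds shown here alone, whether an amine or a carboxylic acid at the same place would move the number beyond the scatter stays open. Compound 1 offers no step for comparison, since its reading is only a limit: the limit of > 50000 nM in this assay, at which 1 of the 3 values shown sits.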